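Solubility step to the 4-fluorophenyl amide, compound 4

The source may hold more compounds than are shown below. What is called first, only, known or untested is meant among the compounds shown, and "the series" means these compounds.

The series shares one core and varies the group on the carbonyl carbon of the piperazine amide. Compound 1 `CC(C)(C)C(=O)N1CCN(c2nc(=O)c3cc(C(F)(F)F)cc([N+](=O)[O-])c3s2)CC1` carries tert-butyl there and in a physicochemical assay for solubility, read by HPLC (a higher number here means a more soluble compound, a lower number a less soluble compound), compound 1 gives 5.87 ug/mL, the second highest of the three numbers in hand. Compound 2 `O=C(c1ccccc1Cl)N1CCN(c2nc(=O)c3cc(C(F)(F)F)cc([N+](=O)[O-])c3s2)CC1` carries 2-chlorophenyl and in this assay compound 2 gives 8.18 ug/mL; the step of a 1.4-fold higher number from compound 1 to compound 2 (0.14 log units; within the scatter) lies within the scatter. Compound 3 `O=C(c1cccc(F)c1)N1CCN(c2nc(=O)c3cc(C(F)(F)F)cc([N+](=O)[O-])c3s2)CC1` carries 3-fluorophenyl and in this assay compound 3 gives 0.2 ug/mL; the step of a 29-fold lower number from compound 1 to compound 3 (1.47 log units; beyond the scatter) is large, as is a 41-fold lower number from compound 2 to compound 3 (1.61 log units; beyond the scatter).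

Compound 4 `O=C(c1ccc(F)cc1)N1CCN(c2nc(=O)c3cc(C(F)(F)F)cc([N+](=O)[O-])c3s2)CC1` is the next member. Its difference from compound 1 is 4-fluorophenyl in place of tert-butyl on a carbonyl carbon. Two steps from tert-butyl to an aryl group bear on this: one stayed flat, one fell hard, and the fall came with the fluorophenyl group. A fluorophenyl group is again entering here, so a clear drop is expected, though its size is uncertain given compound 2. In this assay compound 4 is therefore expected to give about 0.6 ug/mL, within 0.1 ug/mL to 4 ug/mL, which means an expected step of a 9.8-fold lower number from compound 1 to compound 4 (0.99 log units; beyond the scatter).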

Compound 4, solubility: 1.69 ug/mL
The estimate for compound 4 lay 2.8-fold (0.45 log units) below the measured number; measured number inside the range.
By their numbers in this assay, from the lowest: compound 3; then compound 4; then compounds 1 and 2 (each within the scatter of the next).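

In this assay the two fluorophenyl amides do not behave alike: 4-fluorophenyl in place of 3-fluorophenyl gives an 8.5-fold higher number from compound 3 to compound 4 (0.93 log units; beyond the scatter), so the outcome at this carbonyl carbon depends on which fluorophenyl group is attached, not simply on an aryl group being there. The drop on replacing tert-butyl is smaller with this group, at a 3.5-fold lower number from compound 1 to compound 4 (0.54 log units; beyond the scatter), yet still beyond the scatter, and a 4.8-fold lower number from compound 2 to compound 4 (0.68 log units; beyond the scatter) also separates the 4-fluorophenyl amide from the 2-chlorophenyl amide. No measurement shown accounts for these differences.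

The data leave open how the halogen's identity and its place on the ring each contribute, and 3-chlorophenyl, 4-chlorophenyl and unsubstituted phenyl would help separate the two. Also open, on these data alone, is how the number responds when an amine or a carboxylic acid is carried on the group at this carbonyl carbon.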